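Trimming butyl to ethyl: cytotoxicity in RD cells

This account rests on a few compounds, and the source may have more. Where it says the series, first, only, none or still open, it means among the compounds named here.

Compound 1 `CCc1nc(-c2cnc3ccc(-c4ccc(N)nc4)cc3c2)no1`: in a functional assay on RD cells (Homo sapiens) for inhibition, read by luminescence and ATP content, with a stated time of 72 h (a lower number here means that less compound is tolerated, a higher number that more compound is tolerated), compound 1 gives > 66700 nM, which is a limit of the assay.
Compound 2 `CCCCc1ccc(-c2ccc3ncc(-c4noc(CC)n4)cc3c2)cc1`: in this assay compound 2 gives > 7400 nM, which is also a limit of the assay.

Compound 2 therefore stands nowhere definite on the numbers shown: its own result is only a limit (the limit of > 7400 nM in this assay, at which 1 of the 2 values shown sits), and the one further value, that of compound 1, is likewise a limit (the limit of > 66700 nM in this assay, at which 1 of the 2 values shown sits). Within the data shown here, no step between measured compounds can be drawn, and the two limits sit at different concentrations for reasons the data do not give.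

Compound 3 `CCc1ccc(-c2ccc3ncc(-c4noc(CC)n4)cc3c2)cc1` is not yet measured. It differs from compound 2 by hydrogen in place of ethyl on a saturated chain carbon, two bonds along the chain from an aromatic carbon, so the butyl on the outer ring becomes ethyl. Among the measured compounds shown here, because compound 2 gives > 7400 nM as a limit, there is no measured size of step in this assay to lean on; no direction beyond the scatter is expected from removing two chain carbons, and the most likely outcome is again a limit. Compound 3 is expected to give 20000 nM in this assay, within 5000 nM to 80000 nM, an expected step that the limit leaves unreadable from compound 2 to compound 3.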

Compound 3, half-maximal cytotoxic concentration: > 22200 nM
Compound 3 was reported as a limit (the forecaster's own chance of this, stated with the estimate: 80%); middle value at least 1.1-fold (0.04 log units) from the limit.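

Among these compounds, compound 1, compound 2 and compound 3 are all reported in this assay only as limits, and neither the step from compound 2 to compound 3 nor the one from compound 1 to compound 3 can be read. The compounds shown leave open where each reaches its half-maximal cytotoxic concentration, and whether trimming butyl to ethyl changes that concentration at all.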